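Quaternary Ammonium Head Variation on a Quinolone Amide Core

A few compounds are considered here, and "the series" means these few. Any claim that something is new, unique, unknown or untested is made for them only; others in the source may bear on it.

Measured so far:
- Compound 1 `CN(C)c1ccc2c(=O)c(C(=O)Nc3cc(F)cc(F)c3)cn(-c3ccc(OCCCCCCC[N+]45CCN(CC4)CC5)cc3Cl)c2n1`: 40.1%
- Compound 2 `CN(C)c1ccc2c(=O)c(C(=O)Nc3cc(F)cc(F)c3)cn(-c3ccc(OCCCCCCC[N+]4(C)CCCC4)cc3Cl)c2n1`: "not active" (no number reported)
- Compound 3 `CN1CC[N+](C)(CCCCCCCOc2ccc(-n3cc(C(=O)Nc4cc(F)cc(F)c4)c(=O)c4ccc(N(C)C)nc43)c(Cl)c2)CC1`: "not active" (no number reported)

Three compounds that share the same core and the same seven-carbon chain ending in a charged nitrogen have been tested in an assay on LX2 cells for inhibition of COL1A1 promoter (Homo sapiens), read by a luciferase reporter, with a stated time of 24 h, tested at 20 uM; on this read-out lower numbers stand for a weaker effect and higher numbers for a stronger effect at the one concentration tested. Compound 1 gives 40.1%. Compound 2 was reported in this assay as "not active" (no number reported), with no number attached. Compound 3 stands at the same place: in this assay compound 3 was reported as "not active" (no number reported), again without a number, so its standing can only be described as the weak end of what has been seen, alongside compound 2 and clearly apart from compound 1.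

Compound 4 `CN(C)c1ccc2c(=O)c(C(=O)Nc3cc(F)cc(F)c3)cn(-c3ccc(OCCCCCCC[N+](C)(C)C4CCCCC4)cc3Cl)c2n1` has not yet been measured. It differs from compound 3 in one spot: a group of 9 heavy atoms (8 carbon, 1 nitrogen; one six-membered non-aromatic ring of carbon only) in place of a group of 8 heavy atoms (6 carbon, 2 nitrogen; one six-membered non-aromatic ring with 2 hetero atoms), on a saturated chain carbon, seven bonds along the chain from an oxygen on an aromatic ring. Within the data shown here, no measured pair of compounds follows the same kind of change, so the size of this step cannot be read from the data. Two of the three measured charged heads gave no number at all, and only compound 1 gave a clear effect, so the expectation for compound 4 is a small effect, possibly again outside the range that yields a number. Compound 4 is estimated at 15%, within 0% to 40%.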

Compound 4, a percentage reported as inhibition, at one concentration (the size of the read-out at that concentration, not a potency): "not active" (no number reported)
No number was reported for compound 4; no gap can be computed for the estimate.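

In this assay compound 3 and compound 4 both carry no number, so no step can be read between them. No measured evidence bears on this result. Still open, going by these compounds, is whether the carbon-only six-membered ring of compound 4 and the six-membered ring with 2 hetero atoms of compound 3 differ in effect at all.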